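Swapping propyl for tert-butyl on an amide nitrogen

The source may report more compounds than this note shows. Statements on the series, on what has been measured and on what is new or still open speak of the compounds shown alone.

Measured compounds:
Compound 1, `C=CC1=C(C(=O)NCc2ccc(C)cc2)C(c2ccc(F)cc2)OC1`, gives > 100000 nM in a functional assay on A549 cells (Homo sapiens) for cytotoxicity, read by MTT assay, with a stated time of 24 h; on this read-out higher numbers stand for weaker inhibition and lower numbers for stronger inhibition.
Compound 2, `C=CC1=C(C(=O)NCCC)C(c2ccc(Cl)c(Cl)c2)OC1`, gives > 100000 nM in this assay.

Both of these values are limits of this assay, not numbers. For compound 1 the value > 100000 nM is a limit. Within the data shown here, for compound 2 the value > 100000 nM is likewise a limit, so compound 2 stands at the edge of what this assay can report, alongside the only other value shown, as the limit of > 100000 nM in this assay, at which 2 of the 2 values shown sit, records.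

Compound 3, `C=CC1=C(C(=O)NC(C)(C)C)C(c2ccc(Cl)c(Cl)c2)OC1`, has not been measured. It differs from compound 2 in one place: tert-butyl in place of propyl on an amide-type nitrogen. Nothing else in the structure changes; the shared core and the aryl group carrying the two chlorine atoms stay as they are.

With no measured step between any two compounds to lean on, and both shown values sitting at the limit, the step that the limit leaves unreadable from compound 2 to compound 3 is expected to be none beyond the usual scatter. Compound 3 is therefore expected to give about 150000 nM in this assay, within a range from 50000 nM to 500000 nM, most likely reported again only as a limit.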

Compound 3, half-maximal inhibitory concentration: > 100000 nM
Compound 3: no number, only a limit (the forecaster's own chance of this, stated with the estimate: 85%); the middle value lies beyond the limit too.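

Compound 2 and compound 3 both stand only as limits, not as numbers, so the step from propyl to tert-butyl on the amide-type nitrogen cannot be read. The compounds shown leave open whether any of them has a measurable effect in this assay, since all of them end at the same point: the limit of > 100000 nM in this assay, at which 3 of the 3 values shown sit.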